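Aryl swap on the chain carbon of compound 2

The compounds below may be only part of what the source reports. "The series", "measured", "known", "first", "only" and "open" are said of these compounds alone.

Measured compounds:
compound 1 `O=C(/C(=C\c1cc(Cl)c(O)c(Cl)c1)S(=O)(=O)Cc1ccc(Br)cc1)c1ccc(Br)cc1` gives 25000 nM
compound 2 `Cc1cc(C)cc(/C=C(/SCc2ccc(Br)cc2)C(=O)c2ccccc2Cl)c1` gives 10000 nM
compound 3 `Nc1ccc(/C=C(/SCc2ccc(F)cc2)C(=O)c2ccc(C(=O)O)cc2)cc1[N+](=O)[O-]` gives 10000 nM

In a functional assay on DU-145 cells (Homo sapiens) for inhibition, read by trypan blue exclusion, with a stated time of 96 h (on this read-out higher numbers stand for weaker inhibition of growth and lower numbers for stronger inhibition of growth), the three measured compounds lie close together. Compound 2 and compound 3 are level as far as the numbers go, and together they give the lowest numbers of the three; compound 1 gives a higher number than compound 2, a gap beyond the scatter. No two of the measured compounds differ in a single place, so no isolated change in this assay has a known size.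

Compound 4 `O=C(/C(=C\c1ccc(Cl)cc1)SCc1ccc(Br)cc1)c1ccccc1Cl` has not yet been measured in this assay. It differs from compound 2 in one place: 4-chlorophenyl in place of 3,5-dimethylphenyl on a double-bonded chain carbon bound to a double-bonded chain carbon. Within the data shown here, no measured pair speaks to this change directly, and the three numbers in hand span only a narrow range, so the expectation is a step from compound 2 to compound 4 of no size beyond the scatter, in either direction. The estimated value for compound 4 in this assay is 10000 nM, with a range from 4000 nM to 25000 nM. This estimate means an expected step of no change at the digits printed from compound 2 to compound 4 (within the scatter).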

Compound 4, concentration for 50% growth inhibition: 25000 nM
Compound 4: middle estimate off by 2.5-fold (0.40 log units), on the low side; low and high end bracket the measured number.
By their numbers in this assay, from the lowest: compounds 2 and 3 (each within the scatter of the next); then compounds 1 and 4 (each within the scatter of the next).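

In this assay, among these compounds, 4-chlorophenyl in place of 3,5-dimethylphenyl on a double-bonded chain carbon bound to a double-bonded chain carbon gives a 2.5-fold higher number from compound 2 to compound 4 (0.40 log units; beyond the scatter), the first single change of known size. This position is therefore not silent: exchanging one aryl group for another, each with one six-membered aromatic ring of carbon only, no hydrogen-bond donors or acceptors and no net charge, moves the number beyond the scatter. No measurement on these compounds accounts for the step.

This single pair cannot separate the loss of the two methyl groups from the gain of the chlorine. From the compounds shown here alone, how an unsubstituted phenyl or a methoxyphenyl at this position would read also remains open, as does whether the step holds on other versions of the shared core.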